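A methyl added to a weak growth inhibitor

The compounds below may be only part of what the source reports. "The series", "measured", "known", "first", "only" and "open" are said of these compounds alone.

Measured compounds in a functional assay on DWD cells (Homo sapiens) for inhibition, read by sulforhodamine B assay (a higher number here means a weaker inhibitor of growth, a lower number a stronger inhibitor of growth), are these

Compound 1 `Cc1ccc2[nH]c(-c3ccc(-c4ccc(-c5ccc(N(C)C)cc5)cc4)cc3)nc2c1` gives 3230 nM here
Compound 2 `COc1ccc(-c2ccc(-c3ccc(-c4nc5cc(C)ccc5[nH]4)cc3)cc2)cc1OC` gives 1720 nM here
Compound 3 `Fc1ccc(-c2ccc(-c3ccc(-c4nc5ccccc5[nH]4)cc3)cc2)cc1` gives 35600 nM here

Compound 3 stands highest of the three at 35600 nM in this assay and is the weakest inhibitor of growth so far. Compound 4 `Cc1ccc2[nH]c(-c3ccc(-c4ccc(-c5ccc(F)cc5)cc4)cc3)nc2c1` keeps the rest of compound 3 and makes one change, methyl in place of hydrogen on an aromatic carbon with nothing else altered.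

Going by the values given here, no measured step isolates this methyl. Among the compounds with values here, the only step available a 1.9-fold lower number from compound 1 to compound 2 (0.27 log units; within the scatter) exchanges a different group, lies within the scatter, and occurs between two compounds that both carry the methyl. Compound 1 at 3230 nM and compound 2 at 1720 nM both sit well under compound 3, but each also differs from it in that other group, so this is only indirect evidence. A lower number of moderate size is expected, estimated as a 3.6-fold lower number from compound 3 to compound 4 (0.55 log units; beyond the scatter) in this assay with wide uncertainty. For compound 4 the estimated value is 10000 nM within an expected range of 2500 nM to 35000 nM in this rough forecast.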

Compound 4, concentration for 50% growth inhibition: 33100 nM
The estimate for compound 4 lay 3.3-fold (0.52 log units) below the measured number; low and high end bracket the measured number.
By their numbers in this assay, from the lowest: compounds 2 and 1 (each within the scatter of the next); then compounds 4 and 3 (each within the scatter of the next).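

In this assay the methyl on the aromatic carbon of the fused two-ring system changes nothing that can be told from scatter, with a 1.1-fold lower number from compound 3 to compound 4 (0.03 log units; within the scatter) as the step. Keeping that methyl and changing only the other group does make a large difference: 4-fluorophenyl in place of 3,4-dimethoxyphenyl gives a 19-fold higher number from compound 2 to compound 4 (1.28 log units; beyond the scatter) as the step, and fluoro in place of dimethylamino gives a 10-fold higher number from compound 1 to compound 4 (1.01 log units; beyond the scatter) as the step. In this fluoro-bearing pair, then, the methyl alone does not turn a weak inhibitor of growth into a stronger one, and the large steps all come with the exchange of the other group.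

On these data alone, whether the methyl counts for equally little alongside dimethylamino or 3,4-dimethoxyphenyl stays open, as does the effect of an ethyl, a methoxy or an amine on the same carbon. No measurement shown explains why the methyl leaves the number unmoved or why the other group matters so much.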